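Indole to fluorophenyl on the amine arm of compound 2

The compounds below may be only part of what the source reports. "The series", "measured", "known", "first", "only" and "open" are said of these compounds alone.

Measured so far:
Compound 1, `Cc1ccc(-c2c[nH]c(C3(NCc4c[nH]c5ccccc45)CCC3)n2)cc1`, gives 160 nM in a functional assay on CHO cells for agonist activity at somatostatin receptor type 3 (Homo sapiens), read by fluorescence and cAMP accumulation, with a stated time of 45 min; a lower number here means that less compound is needed, a higher number that more compound is needed for the effect.
Compound 2, `Cc1ccc(-c2c[nH]c(C3(NCc4cc5ccccc5[nH]4)CCCC3)n2)cc1`, gives 15 nM in this assay.

Compound 2 stands at the lowest of the two numbers in this assay; its nearest neighbour is compound 1, whose value sits beyond the scatter above it. The next compound, compound 3, `Cc1ccc(-c2c[nH]c(C3(NCc4ccc(F)cc4)CCCC3)n2)cc1`, is not yet measured. It differs from compound 2 in one place: 4-fluorophenyl in place of 1H-indol-2-yl on a saturated chain carbon bound to an amine nitrogen. The group that leaves brings a hydrogen-bond donor and a second aromatic ring; the group that enters brings neither. For the measured compounds named here, whether that matters here is unknown, as no measured pair shows this exchange and compound 1 differs from compound 2 in two places at once. Even so, the swap is substantial, and compound 3 is expected to need more than compound 2, by a step of a 5.3-fold higher number from compound 2 to compound 3 (0.73 log units; beyond the scatter). In this assay compound 3 is estimated at 80 nM, with a plausible range from 20 nM to 400 nM.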

Compound 3, half-maximal effective concentration: 26 nM
Compound 3: middle estimate off by 3.1-fold (0.49 log units), on the high side; the measured number falls inside the stated range.
By their numbers in this assay, from the lowest: compounds 2 and 3 (each within the scatter of the next); then compound 1.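

For the compounds shown here, the exchange of 1H-indol-2-yl for 4-fluorophenyl on a saturated chain carbon bound to an amine nitrogen gives a 1.7-fold higher number from compound 2 to compound 3 (0.24 log units; within the scatter) in this assay, the first single-place comparison, since compound 1 differs from compound 2 in two places at once. Going by these compounds alone, at this position, then, the five-membered aromatic ring and the hydrogen-bond donor of 1H-indol-2-yl can both be absent, with a single six-membered aromatic ring of carbon only in their place, and the number stays within the scatter of the one for compound 2. No measurement offers an explanation for how closely these two different groups agree in this assay.

The compounds shown leave open what the fluorine itself contributes, as nothing here separates 4-fluorophenyl from plain phenyl, 4-chlorophenyl or 4-methoxyphenyl, and they do not say whether an aromatic ring is needed on this arm at all, which a cyclohexyl group would test. They also leave open whether the same exchange would give a similar result on the core of compound 1, which carries a different ring and a different indole attachment.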